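Amide aryl exchange on a trifluoromethyl anilide series

A few compounds are considered here, and "the series" means these few. Any claim that something is new, unique, unknown or untested is made for them only; others in the source may bear on it.

Among the measured compounds shown here, compound 2 `CCN(CC)c1ccc(C(F)(F)F)cc1NC(=O)c1cccnc1Cl` is the only member of the series with a number in a functional assay on Jurkat cells (Homo sapiens) for cytotoxicity, read by MTT assay, with a stated time of 48 h; on this read-out higher numbers stand for weaker inhibition and lower numbers for stronger inhibition: compound 2 gives 88400 nM, a weak effect. Compound 1 `O=C(Nc1cc(C(F)(F)F)ccc1Nc1ccc(Br)cc1)c1ccncc1` carries the pyridin-4-yl amide, and in this assay compound 1 is recorded as "not active" (no number reported), without a number. Compound 3 `CCN(CC)c1ccc(C(F)(F)F)cc1NC(=O)c1ccncc1` is not yet measured. The change from compound 2 to compound 3 is pyridin-4-yl in place of 2-chloropyridin-3-yl on a carbonyl carbon, on a carbonyl carbon whose other neighbour is an amide-type nitrogen. For the measured compounds named here, no step between measured compounds is available, so the size of the step rests on compound 1 alone. Since compound 1 with the same amide shows "not active" (no number reported), a step toward weaker inhibition, or none beyond the scatter, is expected, and an entry without a number is a real possibility. For compound 3 the estimate in this assay is 150000 nM, with a range from 60000 nM to 400000 nM, which means an expected step of a 1.7-fold higher number from compound 2 to compound 3 (0.23 log units; within the scatter).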

Compound 3, half-maximal inhibitory concentration: "not active" (no number reported)
Nothing numeric was reported for compound 3, so the estimate cannot be set against anything.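

Among the compounds shown here, with compound 3 at "not active" (no number reported) and compound 2 at 88400 nM no step between them can be read. No measured property bears on this result. Open remains how far pyridin-4-yl in place of 2-chloropyridin-3-yl shifts the effect on the shared core.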